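Fluorine on the methylphenyl ring: a small change

A few compounds are considered here, and "the series" means these few. Any claim that something is new, unique, unknown or untested is made for them only; others in the source may bear on it.

Compound 1 `Cc1ccccc1-c1ccc(C(O)CCCCCO)cc1` is the parent here. In a functional assay on J774 cells (Mus musculus) for cytotoxicity, read by resazurin assay (a lower number here means a stronger inhibitor, a higher number a weaker inhibitor), compound 1 gives 24000 nM, the highest of the two numbers shown, with compound 3 `OCCCCCC(O)c1ccc(-c2ccc(Cl)cc2)cc1` closest at 17000 nM; the step of a 1.4-fold lower number from compound 1 to compound 3 (0.15 log units; within the scatter). Compound 2 `OCCCCCC(O)c1ccc(-c2cccc(Cl)c2)cc1` gives only a limit, > 100000 nM, the assay reporting nothing more precise (the limit of > 100000 nM in this assay, at which 1 of the 3 values shown sits). The steps of an at least 4.1-fold higher number from compound 1 to compound 2 (0.61 log units; beyond the scatter) and an at least 5.8-fold lower number from compound 2 to compound 3 (0.76 log units; beyond the scatter) are the only ones beyond the scatter, and both replace the whole outer ring.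

Compound 4 `Cc1cc(F)ccc1-c1ccc(C(O)CCCCCO)cc1` keeps the 2-methylphenyl group of compound 1 and differs from it by one atom: fluoro in place of hydrogen on an aromatic carbon. Among the measured compounds shown here, no measured step adds a single small substituent to an otherwise unchanged ring, so none bears on it directly; the measured steps show that swapping the outer ring moves the number by at most a modest amount, and a lone fluoro is a smaller change than any of them. No step beyond the scatter is therefore expected. Compound 4 is estimated at 20000 nM, likely between 8000 nM and 50000 nM. For compound 4 this means an expected step of a 1.2-fold lower number from compound 1 to compound 4 (0.08 log units; within the scatter).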

Compound 4, half-maximal inhibitory concentration: 20000 nM
Estimate against measurement, compound 4: no gap at the digits printed; low and high end bracket the measured number.
By their numbers in this assay, from the lowest: compounds 3, 4 and 1 (each within the scatter of the next). At a limit, above all of these: compound 2.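

Among the compounds shown here, with fluoro in place of hydrogen on an aromatic carbon, this assay records only a 1.2-fold lower number from compound 1 to compound 4 (0.08 log units; within the scatter), and this is the one measured change here that keeps the 2-methylphenyl group in place. For the compounds shown here, at this position, meta to a methyl group and para to a large group, a lone fluoro therefore gives no step beyond the scatter, whereas the steps beyond the scatter among the earlier compounds each replaced the whole outer ring. Nothing measured here gives a reason for this result.

On these data alone, whether a larger group at this position, such as a methoxy group, a nitrile or an amine, would also leave the number within the scatter stays open, as does fluoro elsewhere on this ring. The compounds shown also leave open what a longer chain or a carboxylic acid on the chain would do.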